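This account rests on a few compounds, and the source may have more. Where it says the series, first, only, none or still open, it means among the compounds named here.

Of the compounds shown here, two that share a core have been measured so far in a functional assay on HepG2 cells (Homo sapiens) for inhibition, read by MTT assay, with a stated time of 24 h; on this read-out lower numbers stand for stronger inhibition and higher numbers for weaker inhibition. Compound 1 `CC1(C)[C@H]2CC[C@]1(C)N(Cc1cn(-c3ccccc3Cl)nn1)C(=O)C2`, which carries a 2-chlorophenyl on an aromatic nitrogen, gives 60 nM. Compound 2 `Cc1ccc(-n2cc(CN3C(=O)C[C@@H]4CC[C@@]3(C)C4(C)C)nn2)cc1`, with a 4-methylphenyl in that place, gives 480 nM, the higher of the two numbers and therefore the weaker inhibition.

Compound 3 `CC1(C)[C@H]2CC[C@]1(C)N(Cc1cn(-c3cccc(O)c3)nn1)C(=O)C2` keeps the same core and changes that group once more, to a 3-hydroxyphenyl: 3-hydroxyphenyl in place of 4-methylphenyl on an aromatic nitrogen. Among the measured compounds shown here, only one measured step bears on this change, an 8.0-fold higher number from compound 1 to compound 2 (0.90 log units; beyond the scatter). It is modest but beyond the scatter, and it shows that swapping the group on this aromatic nitrogen can move the number. That step involves a different pair of groups, so it is a guide to size and a weak guide to direction. For the measured compounds named here, with compound 2 at 480 nM, the higher of only two values, a modest move toward a lower number in this assay is the more likely outcome, an estimated step of a 2.4-fold lower number from compound 2 to compound 3 (0.38 log units; beyond the scatter). The estimated value for compound 3 is 200 nM, with an expected range of 50 nM to 800 nM.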

Compound 3, half-maximal inhibitory concentration: 70 nM
For compound 3 the middle estimate is 2.9-fold (0.46 log units) above the measured one; the measured number falls inside the stated range.
By their numbers in this assay, from the lowest: compounds 1 and 3 (each within the scatter of the next); then compound 2.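

Replacing the 4-methylphenyl on the aromatic nitrogen with a 3-hydroxyphenyl gives a 6.9-fold lower number from compound 2 to compound 3 (0.84 log units; beyond the scatter) in this assay, so a change at this position can also lower the number from compound 2, not only raise it as the earlier step did. The 2-chlorophenyl and the 3-hydroxyphenyl carry different atoms on the phenyl ring at different places, yet they give a 1.2-fold higher number from compound 1 to compound 3 (0.07 log units; within the scatter), so at this position two quite different groups can give numbers that cannot be told apart, and compound 2 remains the weakest of the three. The data shown offer no measured property or other evidence that explains why the 4-methylphenyl stands apart from the other two groups.

Each of the three groups differs from the others in both the atoms attached to the phenyl ring and where they sit, so these compounds cannot separate the effect of one from the other. On these data alone, a plain phenyl, a 3-methylphenyl or a 4-hydroxyphenyl would pull those two apart, and how an amine or a carboxylic acid on the phenyl ring would read here remains open.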